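This account rests on a few compounds, and the source may have more. Where it says the series, first, only, none or still open, it means among the compounds named here.

Measured so far:
compound 1 `OCCC(F)C(F)F`, 0.29
compound 2 `OCCCCF`, 0.09
compound 3 `OCCCCC(F)F`, 0.66

In a physicochemical assay for lipophilicity, read by NMR (a higher number here means a more lipophilic compound, a lower number a more polar compound), compound 3 gives 0.66, the highest of the three numbers. The nearest of the other two is compound 1, which in this assay gives 0.29, a gap that lies beyond the scatter. The furthest is compound 2, which gives 0.09, again beyond the scatter. Among the measured compounds shown here, no pair among the measured compounds differs in a single place, so no measured step is available to carry over to the next compound.

Compound 4 `OCCCC(F)C(F)F` is the next compound for this assay. It differs from compound 3 in one place: fluoro in place of hydrogen on a saturated chain carbon bound to two saturated chain carbons. For the measured compounds named here, compound 1 carries the same arrangement of fluorine atoms as compound 4 on its own shorter core, and its value in this assay is lower than that of compound 3; no step between compound 1 and compound 4 is given, so only the two numbers can be set side by side.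

For compound 4 a step of about a number 0.04 log units higher from compound 3 to compound 4 (within the scatter) is expected in this assay, a change that would stay within the scatter. Compound 4 is therefore estimated at 0.7, with a range from 0.4 to 1.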

Compound 4, partition coefficient: 0.52
Compound 4: the middle estimate sits 0.18 log units above what was measured; the measured number falls inside the stated range.
By their numbers in this assay, from the lowest: compounds 2, 1, 4 and 3 (each within the scatter of the next, the first and the last beyond it).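

In this assay, fluoro in place of hydrogen on a saturated chain carbon bound to two saturated chain carbons gives a number 0.14 log units lower from compound 3 to compound 4 (within the scatter), so at this position the added fluorine leaves no change that can be separated from the scatter. The step that does clear the scatter is difluoromethyl in place of hydrogen on a saturated chain carbon bound to a fluorine atom and a saturated chain carbon, which gives a number 0.43 log units higher from compound 2 to compound 4 (beyond the scatter), and it is a modest one. Hydroxymethyl in place of hydroxy on a saturated chain carbon, three bonds along the chain from a fluorine atom, gives a number 0.23 log units higher from compound 1 to compound 4 (within the scatter), so this change to the chain cannot be told apart from repeat variation in this series.

Nothing at hand bears on why these steps have the sizes they do. Still open, on these data alone, is whether the same fluoro for hydrogen change stays this small on a longer chain, or with an amine or a carboxylic acid in place of the hydroxy.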